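Sulfamoylphenyl for Methoxyphenyl on an Inactive Spiro Series

This account rests on a few compounds, and the source may have more. Where it says the series, first, only, none or still open, it means among the compounds named here.

Compound 1 `N#CC1=C(N)Oc2c(c3nc4ccccc4nc3c3ccccc23)C12C(=O)N(Cc1cnnn1-c1cccc(Cl)c1)c1ccccc12` in a functional assay on HCT-116 cells (Homo sapiens) for antiproliferative activity, read by MTT assay, with a stated time of 48 h; on this read-out lower numbers stand for stronger inhibition and higher numbers for weaker inhibition: > 50000 nM
Compound 2 `COc1ccc(-n2nncc2CN2C(=O)C3(C(C#N)=C(N)Oc4c3c3nc5ccccc5nc3c3ccccc43)c3ccccc32)cc1` in this assay: > 50000 nM

In this assay compound 1 reaches only a limit of the assay, > 50000 nM. In this assay compound 2 likewise reaches only a limit, > 50000 nM. Among the compounds with values here, the single measured step, a step that the two limits leave unreadable from compound 1 to compound 2, is therefore unreadable, since both of its ends sit at the limit of > 50000 nM in this assay, at which 2 of the 2 values shown sit. Compound 2 thus stands at the limit, with no number of its own to anchor a comparison.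

Compound 3 `N#CC1=C(N)Oc2c(c3nc4ccccc4nc3c3ccccc23)C12C(=O)N(Cc1cnnn1-c1cccc(S(N)(=O)=O)c1)c1ccccc12` carries 3-sulfamoylphenyl in place of 4-methoxyphenyl on an aromatic nitrogen. Within the data shown here, no measured step bears readably on this change, so no size or direction of step in this assay can be expected beyond the pattern that both measured compounds sit at the limit. Compound 3 is expected to give 60000 nM in this assay, within 20000 nM to 200000 nM, most likely again reported as a limit. The expected step is a step that the limit leaves unreadable from compound 2 to compound 3.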

Compound 3, half-maximal inhibitory concentration: 11300 nM
Beside the measured number, compound 3's estimate is 5.3-fold (0.73 log units) above it; the whole stated range lies above it.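

On this assay, the 3-sulfamoylphenyl group on the aromatic nitrogen gives this series its first readable number, with an at least 4.4-fold lower number from compound 2 to compound 3 (0.64 log units; beyond the scatter). The comparison with the chlorinated analogue points the same way, with an at least 4.4-fold lower number from compound 1 to compound 3 (0.64 log units; beyond the scatter). This shows that the aryl group at this position can shift the antiproliferative read-out, which the two earlier compounds could not show, but the true size of both steps stays unknown, since each starts from a limit: the limit of > 50000 nM in this assay, at which 2 of the 3 values shown sit.

The compounds shown leave open whether the sulfamoyl group is specifically needed or whether another group in the same place, such as a carboxylic acid or a methylsulfonyl group, would serve as well. They also leave open how much further the number could fall, as a single readable value defines no trend.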